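The compounds below may be only part of what the source reports. "The series", "measured", "known", "first", "only" and "open" are said of these compounds alone.

Compound 1 `CCCC/C=C\CCCCCCCCCC1(O)CC(=O)c2c(O)cc(OCOC)cc2O1` bears its chain on a saturated ring carbon. In a functional assay on MCF7 cells (Homo sapiens) for antiproliferative activity, read by MTT assay (on this read-out lower numbers stand for stronger inhibition and higher numbers for weaker inhibition), compound 1 gives 43200 nM. Compound 2 `CCCCC/C=C\C/C=C\CCCCCCCC1(O)CC(=O)c2c(O)cc(OCOC)cc2O1` differs from it by deca-1,4-dien-1-yl in place of oct-3-en-1-yl on a saturated chain carbon, seven bonds along the chain from a saturated ring carbon. For compound 2 only a limit is known in this assay, > 84100 nM. The step of an at least 1.9-fold higher number from compound 1 to compound 2 (0.28 log units; that floor lies within the scatter) is therefore hard to read, since the value the limit of > 84100 nM in this assay, at which 1 of the 3 values shown sits, is a limit rather than a number.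

Compound 3 `CCCC/C=C\CCCCCCCCCc1cc(=O)c2c(O)cc(OCOC)c(C)c2o1` has a different core, with the chain on an aromatic carbon; the difference between its core and the core of compound 1 is not broken down here. For compound 3 only a limit is known in this assay, > 67200 nM. Compound 4 `CCCCC/C=C\C/C=C\CCCCCCCc1cc(=O)c2c(O)cc(OCOC)c(C)c2o1` is unmeasured and differs from compound 3 by deca-1,4-dien-1-yl in place of oct-3-en-1-yl on a saturated chain carbon, seven bonds along the chain from an aromatic carbon, the same kind of change as between compound 1 and compound 2, though the place here lies seven bonds along the chain from an aromatic carbon rather than from a saturated ring carbon.

Given that compound 3 already sits at the limit (the limit of > 67200 nM in this assay, at which 1 of the 3 values shown sits), and that the same kind of change gave an at least 1.9-fold higher number from compound 1 to compound 2 (0.28 log units; that floor lies within the scatter), the step that the limit leaves unreadable from compound 3 to compound 4 is expected to be small, most likely ending again at a limit. Compound 4 is estimated at 110000 nM, within a range from 50000 nM to 350000 nM.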

Compound 4, half-maximal inhibitory concentration: > 84100 nM
Compound 4: only a limit was reported (the forecaster's own chance of this, stated with the estimate: 85%); the middle value is on the limit's open side.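

In this assay compound 3 and compound 4 each give only a limit rather than a number, so no step can be read between them. The compounds shown leave open how strongly either compound acts on these cells, and whether deca-1,4-dien-1-yl in place of oct-3-en-1-yl changes the result on this core.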